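The compounds below may be only part of what the source reports. "The series", "measured", "known", "first", "only" and "open" are said of these compounds alone.

Measured compounds:
compound 1 `CS(=O)(=O)c1ccc(-n2c(=O)n(Cc3cc4cc(Cl)ccc4n3CCCC#N)c3cnccc32)cc1` — > 50000 nM
compound 2 `COc1ccc(-n2c(=O)n(Cc3cc4cc(Cl)ccc4n3CCCC#N)c3cnccc32)cc1OC` — > 50000 nM
compound 3 `N#CCCCn1c(Cn2c(=O)n(-c3ccc(C(=O)NC4CC4)cc3)c3ccncc32)cc2cc(Cl)ccc21` — > 50000 nM

In an ADME assay on HeLa cells (Homo sapiens) for cytotoxicity, read by ATP content, with a stated time of 3 days (on this read-out lower numbers stand for higher toxicity in this test and higher numbers for lower toxicity in this test), compound 1 gives > 50000 nM, a limit of the assay. Compound 2 likewise gives > 50000 nM, a limit. Compound 3 gives > 50000 nM, again a limit, so compound 3 stands at the top of what this assay reports, where all three values shown sit (the limit of > 50000 nM in this assay, at which 3 of the 3 values shown sit). The steps among them, a step that the two limits leave unreadable from compound 1 to compound 2, a step that the two limits leave unreadable from compound 1 to compound 3 and a step that the two limits leave unreadable from compound 2 to compound 3, are therefore unreadable.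

Compound 4 `Cc1ccc(-n2c(=O)n(Cc3cc4cc(Cl)ccc4n3CCCC#N)c3cnccc32)cc1` differs from compound 3 by methyl in place of cyclopropylcarbamoyl on an aromatic carbon. Going by the values given here, no measured step gives a readable size for a change of this kind, and no step beyond the scatter is expected. The expected step is a step that the limit leaves unreadable from compound 3 to compound 4. Compound 4 is estimated at 70000 nM, with a range from 30000 nM to 200000 nM, most likely again as a limit.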

Compound 4, half-maximal cytotoxic concentration: > 50000 nM
Compound 4: a limit, no number (the forecaster's own chance of this, stated with the estimate: 80%); the middle value lies beyond the limit too.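

In this assay, going by these compounds alone, compound 4 gives > 50000 nM, a limit, so no step to compound 4 from compound 1, compound 2 or compound 3 can be read. The compounds shown leave open whether any of these phenyl substituents changes cytotoxicity, and at what concentration any of the four would reach its half-maximal effect.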